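The source may report more compounds than this note shows. Statements on the series, on what has been measured and on what is new or still open speak of the compounds shown alone.

Among the compounds with values here, compound 2 `COc1ccccc1Oc1c(N)nc(-c2ccc(C)cc2)nc1OCCO` gives 8430 nM in a functional assay on B16 cells (Mus musculus) for cytotoxicity, read by CCK-8 assay, with a stated time of 24 h (on this read-out higher numbers stand for weaker inhibition and lower numbers for stronger inhibition), the lowest of the two numbers known so far. Within the data shown here, its only neighbour is compound 1 `COc1ccccc1Oc1c(N)nc(-c2cccc(C)c2)nc1OCCO`, which in this assay gives 70900 nM; the step of an 8.4-fold lower number from compound 1 to compound 2 (0.92 log units; beyond the scatter) came from placing the methyl elsewhere on the phenyl ring. Compound 3 `COc1ccccc1Oc1c(N)nc(-c2ccccc2F)nc1OCCO` is the next compound, and (2-fluorophenyl in place of 4-methylphenyl on an aromatic carbon). Among the measured compounds shown here, the one measured step bears on this only loosely: it shows that where a single group sits on that phenyl ring can shift the number by a modest amount, but no measured pair exchanges a methyl for a fluorine. A shift of similar size, most likely toward a higher number than compound 2, is therefore expected, with the direction uncertain. Compound 3 is estimated at 16000 nM in this assay, within 4000 nM to 60000 nM, which corresponds to an expected step of a 1.9-fold higher number from compound 2 to compound 3 (0.28 log units; within the scatter).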

Compound 3, half-maximal inhibitory concentration: 11800 nM
Beside the measured number, compound 3's estimate is 1.4-fold (0.13 log units) above it; measured number inside the range.
By their numbers in this assay, from the lowest: compounds 2 and 3 (each within the scatter of the next); then compound 1.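

Read in this assay, the step of a 1.4-fold higher number from compound 2 to compound 3 (0.15 log units; within the scatter) stays within the scatter, so on the aromatic carbon between two ring nitrogen atoms, 2-fluorophenyl and 4-methylphenyl cannot be told apart, although they differ in both the group and its place on the phenyl ring. Within the data shown here, the step of a 6.0-fold lower number from compound 1 to compound 3 (0.78 log units; beyond the scatter) lies beyond the scatter and shows that the low numbers at this position are not confined to 4-methylphenyl, leaving 3-methylphenyl in compound 1 as the one group of the three that stands apart. No measurement given here offers a reason for these differences.

The three compounds do not separate the effect of the fluorine from that of its place on the phenyl ring. They also leave open how an amine or a carboxylic acid on that ring would read.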